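A few compounds are considered here, and "the series" means these few. Any claim that something is new, unique, unknown or untested is made for them only; others in the source may bear on it.

Measured compounds in a functional assay on LoVo cells (Homo sapiens) for cytotoxicity, read by MTT assay, with a stated time of 72 h; on this read-out higher numbers stand for weaker inhibition and lower numbers for stronger inhibition:
compound 1, `O=C(Nc1ccc(-n2ncc3c(Cl)cccc32)cc1)Nc1ccc(Cl)c(C(F)(F)F)c1`, gives 3600 nM
compound 2, `Cc1cccc2c1cnn2-c1ccc(NC(=O)Nc2ccc(Cl)c(C(F)(F)F)c2)cc1`, gives 3900 nM
compound 3, `O=C(Nc1ccc(-n2ncc3ccccc32)cc1)Nc1ccc(Cl)c(C(F)(F)F)c1`, gives 8700 nM

Compound 1 stands at the lowest number of the three. Compound 2 sits alongside it: the change is a 1.1-fold higher number from compound 1 to compound 2 (0.03 log units; within the scatter). Compound 3 lies further off, with a 2.4-fold higher number from compound 1 to compound 3 (0.38 log units; beyond the scatter), and the same ordering appears again in a 2.2-fold higher number from compound 2 to compound 3 (0.35 log units; beyond the scatter).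

Compound 4, `CNc1cccc2c1cnn2-c1ccc(NC(=O)Nc2ccc(Cl)c(C(F)(F)F)c2)cc1`, differs from compound 1 by methylamino in place of chloro on an aromatic carbon. Two of the measured steps bear on this position directly. Replacing chloro with methyl, from compound 1 to compound 2, left the number essentially unchanged, while removing the substituent altogether, from compound 1 to compound 3, raised it modestly. Among the measured compounds shown here, a substituent at this carbon thus seems to help a little, but the data give no step in which a hydrogen-bond donor or acceptor enters there, so the direction for methylamino is uncertain. A step within the scatter, or at most a modest rise, is the reasonable expectation in this assay.

Compound 4 is therefore expected to give about 4500 nM, within roughly 2000 nM to 10000 nM, which corresponds to an expected 1.3-fold higher number from compound 1 to compound 4 (0.10 log units; within the scatter).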

Compound 4, half-maximal inhibitory concentration: 6300 nM
Estimate against measurement, compound 4: 1.4-fold (0.15 log units) below; measured number inside the range.
By their numbers in this assay, from the lowest: compounds 1, 2, 4 and 3 (each within the scatter of the next, the first and the last beyond it).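

In this assay, among the compounds shown here, the methylamino group is the first substituent at this aromatic carbon to carry a hydrogen-bond donor and a hydrogen-bond acceptor, and the number it gives cannot be separated from any of the three earlier compounds: a 1.8-fold higher number from compound 1 to compound 4 (0.24 log units; within the scatter), a 1.6-fold higher number from compound 2 to compound 4 (0.21 log units; within the scatter) and a 1.4-fold lower number from compound 3 to compound 4 (0.14 log units; within the scatter). Compound 1 and compound 3 lie beyond the scatter of each other, yet compound 4 lies within the scatter of both, so this result does not place methylamino with chloro and methyl or with hydrogen. What it does show is that this carbon accepts a group with a nitrogen in place of chloro, methyl or hydrogen without a step beyond the scatter in this assay.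

The compounds shown leave open how dimethylamino, methoxy or a longer amine chain would read at this carbon, and so whether the hydrogen on the methylamino nitrogen matters at all. No supporting data are available to explain the values of compound 4 or its steps.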